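Three measured chloroanilides and one expected value

This account rests on a few compounds, and the source may have more. Where it says the series, first, only, none or still open, it means among the compounds named here.

Measured in a functional assay on KB cells (Homo sapiens) for inhibition, read by MTT assay, with a stated time of 24 h, tested at 0.1 ug/mL; on this read-out higher numbers stand for more inhibition of growth at the one concentration tested and lower numbers for less inhibition of growth:
Compound 1, `CC(=O)SCCC(CCCCC(=O)O)SC(C)=O`, gives 7.24%.
Compound 2, `CC(=O)SCCC(CCCCC(=O)Nc1ccccc1Cl)SC(C)=O`, gives 7.05%.
Compound 3, `CC(=O)SCCC(CCCCC(=O)Nc1cccc(Cl)c1)SC(C)=O`, gives 5.72%.

Compound 3 stands within the scatter of both other compounds: a number 1.5 percentage points lower from compound 1 to compound 3 (within the scatter) and a number 1.3 percentage points lower from compound 2 to compound 3 (within the scatter). Compound 4, `CC(=O)SCCC(CCCCC(=O)Nc1ccc(Cl)cc1)SC(C)=O`, differs from compound 3 by 4-chlorophenyl in place of 3-chlorophenyl on an amide-type nitrogen. Among the measured compounds shown here, the steps that bear on this change are a number 0.2 percentage points lower from compound 1 to compound 2 (within the scatter), a number 1.5 percentage points lower from compound 1 to compound 3 (within the scatter) and a number 1.3 percentage points lower from compound 2 to compound 3 (within the scatter); every change so far made at the amide nitrogen has left the read-out where it was. The account therefore expects no step beyond the scatter, a number 0.8 percentage points higher from compound 3 to compound 4 (within the scatter), and estimates for compound 4 a value of 6.5%, expected to lie between -3% and 16%.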

Compound 4, percent growth inhibition at one concentration: 11.4%
Compound 4: the middle estimate sits 4.9 percentage points below what was measured; measured number inside the range.
By their numbers in this assay, from the lowest: compounds 3, 2, 1 and 4 (each within the scatter of the next).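

In this assay, 4-chlorophenyl in place of 3-chlorophenyl on the amide-type nitrogen gives a number 5.7 percentage points higher from compound 3 to compound 4 (within the scatter) and 4-chlorophenyl in place of 2-chlorophenyl gives a number 4.4 percentage points higher from compound 2 to compound 4 (within the scatter) while (4-chlorophenyl)amino in place of hydroxy on the carbonyl carbon gives a number 4.2 percentage points higher from compound 1 to compound 4 (within the scatter) at this same site. The 4-chlorophenyl thus joins the other two chlorophenyl groups in leaving the read-out unseparated from compound 1 at the one concentration tested. No evidence at hand bears on this result.

The compounds shown leave open whether a 4-aminophenyl or 4-carboxyphenyl group on the amide-type nitrogen would step beyond the scatter. The same holds for a longer chain on the carbonyl carbon.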